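A few compounds are considered here, and "the series" means these few. Any claim that something is new, unique, unknown or untested is made for them only; others in the source may bear on it.

Compound 1 `Cc1c(Cc2c(F)cccc2Cl)nc(SCC(=O)c2ccc(F)cc2)[nH]c1=O` and compound 2 `CC(C)c1c(Cc2c(F)cccc2Cl)nc(SCC(=O)c2ccccc2)[nH]c1=O` have both been tested in an ADME assay on MT4 cells (Homo sapiens) for cytotoxicity, read by MTT assay; on this read-out higher numbers stand for lower toxicity in this test and lower numbers for higher toxicity in this test. For compound 1 the result is a limit, > 59000 nM, and not an exact number. For compound 2 the result is also only a limit, > 12000 nM, so compound 2 has no exact value to stand on.

Compound 3 `CC(C)c1c(Cc2c(F)cccc2Cl)nc(SCC(=O)c2ccc(F)cc2)[nH]c1=O` is compound 2 with a single change, fluoro in place of hydrogen on an aromatic carbon, para to a large group, turning phenyl into 4-fluorophenyl. Compound 1 already carries that 4-fluorophenyl group, and its reading of > 59000 nM is a limit as well.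

In this assay the estimated step is a step that the limit leaves unreadable from compound 2 to compound 3, which is expected to stay within the usual scatter, with no direction favoured. For compound 3 the expected value is 15000 nM, with an estimated range from 6000 nM to 50000 nM.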

Compound 3, half-maximal cytotoxic concentration: > 56000 nM
Compound 3 was reported as a limit; the forecaster's own chance of this, stated with the estimate: 65%; middle value at least 3.7-fold (0.57 log units) away from the limit.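

In this assay, among these compounds, compound 1, compound 2 and compound 3 all give limits and not exact numbers, so no step from compound 2 or compound 1 to compound 3 can be read. As far as these compounds go, whether the added fluoro or the isopropyl in place of methyl shifts cytotoxicity stays open.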